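The source may hold more compounds than are shown below. What is called first, only, known or untested is meant among the compounds shown, and "the series" means these compounds.

Measured compounds:
- compound 1, `Cn1ccc(N2C[C@H](CN)OC2=O)c1`: 180000 nM
- compound 2, `CCn1ccc(N2C[C@H](CN)OC2=O)c1`: 25000 nM
- compound 3, `CNC[C@H]1CN(c2ccn(C)c2)C(=O)O1`: > 100000 nM

All three were tested in an assay for inhibition of Amine oxidase [flavin-containing] B (Bos taurus), read by fluorescence, with a stated time of 30 min; a lower number here means a stronger inhibitor, a higher number a weaker inhibitor. Compound 1, `Cn1ccc(N2C[C@H](CN)OC2=O)c1`, gives 180000 nM in this assay. Compound 2 carries one more carbon, a change read as methyl in place of hydrogen on a saturated chain carbon bound to an aromatic nitrogen, and with it the number moves by a 7.2-fold lower number from compound 1 to compound 2 (0.86 log units; beyond the scatter). For compound 3 this assay reports only a limit, > 100000 nM, which is not a number. Compound 3 differs from compound 1 by methyl in place of hydrogen on an amine nitrogen; the size of that step, a step that the limit leaves unreadable from compound 1 to compound 3, cannot be read, because compound 3 sits at the limit of > 100000 nM in this assay, at which 1 of the 3 values shown sits.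

Compound 4, `CCn1ccc(N2C[C@H](CNC)OC2=O)c1`, has not yet been measured. It stands to compound 3 as compound 2 stands to compound 1: the change is methyl in place of hydrogen on a saturated chain carbon bound to an aromatic nitrogen, and the place is the same, word for word, as in the change from compound 1 to compound 2. Among the compounds with values here, the one measured instance of this change, a 7.2-fold lower number from compound 1 to compound 2 (0.86 log units; beyond the scatter), therefore serves as the guide for the expected step from compound 3 to compound 4. Because compound 3 is known only as a limit, the starting point is uncertain, and the result may well remain a limit too. Compound 4 is estimated at 60000 nM, with a likely range from 15000 nM to 300000 nM. This estimate corresponds to an expected step of an at least 1.6-fold lower number from compound 3 to compound 4 (0.22 log units; that floor lies within the scatter), assumed to resemble the step seen between compound 1 and compound 2.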

Compound 4, inhibition constant: 18000 nM
Beside the measured number, compound 4's estimate is 3.3-fold (0.52 log units) above it, within the range that was stated.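

In this assay, methyl in place of hydrogen on a saturated chain carbon bound to an aromatic nitrogen, which turns the methyl group into ethyl, has now been seen on two cores, and the two results can be set side by side: the same change on two cores in this assay, a 7.2-fold lower number (0.86 log units; beyond the scatter) from compound 1 to compound 2 and an at least 5.5-fold lower number (0.74 log units; beyond the scatter) from compound 3 to compound 4; the limit leaves it open whether they differ

The second step, an at least 5.5-fold lower number from compound 3 to compound 4 (0.74 log units; beyond the scatter), is only a floor, so the change carries over in direction from one core to the other, but the data do not show whether its size is the same on both. In this assay compound 3 has only a limit, > 100000 nM, which is not a number, and the step to it from compound 1 cannot be read.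

With ethyl in place, methyl in place of hydrogen on an amine nitrogen gives a 1.4-fold lower number from compound 2 to compound 4 (0.14 log units; within the scatter), so the compounds shown give no sign that this methyl matters on the ethyl core, and they leave open whether the same holds for a larger group on that amine nitrogen, such as ethyl. They also leave open what a longer chain such as propyl, or a ring such as cyclopropyl, would do in place of the ethyl group, and whether the trend seen from methyl to ethyl continues.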